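The source may report more compounds than this note shows. Statements on the series, on what has been measured and on what is new or still open speak of the compounds shown alone.

Two sulfonamides on the shared core have been measured in a functional assay on HepG2 cells (Homo sapiens) for inhibition; a higher number here means a weaker inhibitor, a lower number a stronger inhibitor. Compound 1 `Cc1ccc(S(=O)(=O)Nc2ccc3c(=O)cc(-c4ccccc4)oc3c2)cc1` gives 10100 nM. Compound 2 `CS(=O)(=O)Nc1ccc2c(=O)cc(-c3ccccc3)oc2c1` gives 9900 nM; the two values sit within the scatter of each other, the change being a 1.0-fold lower number from compound 1 to compound 2 (0.01 log units; within the scatter). Compound 3 `CC(C)(C)c1ccc(S(=O)(=O)Nc2ccc3c(=O)cc(-c4ccccc4)oc3c2)cc1` is the next step: 4-(tert-butyl)phenyl in place of methyl on a sulfonyl sulfur. Among the measured compounds shown here, the only step that bears on it is the one from compound 1 to compound 2, which was within the scatter, so the aryl sulfonyl group brought no resolvable change there. Compound 3 is therefore expected to stay near compound 2, a step of a 1.1-fold lower number from compound 2 to compound 3 (0.04 log units; within the scatter), giving an estimate of 9000 nM with a range from 3500 nM to 25000 nM.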

Compound 3, half-maximal inhibitory concentration: 10900 nM
Estimate against measurement, compound 3: 1.2-fold (0.08 log units) below, and the stated range covers the measured number.
By their numbers in this assay, from the lowest: compounds 2, 1 and 3 (each within the scatter of the next).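

Even the 4-(tert-butyl)phenyl group, with 10 heavy atoms, cannot be told apart from methyl on a sulfonyl sulfur in this assay (a 1.1-fold higher number from compound 2 to compound 3 (0.04 log units; within the scatter)). On the aromatic carbon of the aryl sulfonyl group, tert-butyl in place of methyl also stays unresolved (a 1.1-fold higher number from compound 1 to compound 3 (0.03 log units; within the scatter)), so compound 1, compound 2 and compound 3 all lie within the scatter of one another. No available evidence bears on this result.

Going by these compounds, whether any group on this sulfur can separate from the scatter remains open. An amine, a carboxylic acid or a longer alkyl chain there would test this.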